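A few compounds are considered here, and "the series" means these few. Any claim that something is new, unique, unknown or untested is made for them only; others in the source may bear on it.

Working notes on the series in an ADME assay on RAW264.7 cells (Mus musculus) for cytotoxicity, read by MTT assay, with a stated time of 24 h, tested at 5 ug/mL; on this read-out higher numbers stand for a weaker effect at the one concentration tested and lower numbers for a stronger effect.

Of the compounds shown here, three have numbers so far. Compound 1 `COc1ccc(CCCc2ccc(OC)cc2OC)c(O)c1` gives 91.5% in this assay. Compound 2 `COc1ccc(/C=C/C(=O)c2ccc(OC)c(OC)c2)cc1` gives 78.9% in this assay. Compound 3 `COc1ccc(C(=O)/C=C/c2ccc(OC)c(OC)c2OC)c(O)c1` gives 72.5% in this assay. On these three numbers compound 2 stands second highest. Its nearest neighbour is compound 3, whose value lies within the scatter of that of compound 2, so no order between the two can be read. The furthest is compound 1, whose value lies higher by an amount beyond the scatter.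

Compound 4 `COc1ccc(/C=C/C(=O)c2ccc(OC)c(OC)c2)cc1OC` has no number yet. It differs from compound 2 by methoxy in place of hydrogen on an aromatic carbon, the new group sitting ortho to a methoxy group and meta to a large group. For the measured compounds named here, no pair of measured compounds shows a step of this kind, so nothing in the measured set tells the size. Given the spread among compounds 1, 2 and 3, the expected step in this assay is small and none beyond the scatter, with no direction favoured.

For compound 4 the estimated value in this assay is 78%, with a range from 64% to 92%. The expected step of a number 0.9 percentage points lower from compound 2 to compound 4 (within the scatter) is therefore near zero.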

Compound 4, a percentage reported as activity, at one concentration (the size of the read-out at that concentration, not a potency): 81.3%
For compound 4 the middle estimate is 3.3 percentage points below the measured one; the measured number falls inside the stated range.
By their numbers in this assay, from the lowest: compounds 3, 2 and 4 (each within the scatter of the next); then compound 1.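

In this assay, for the compounds shown here, methoxy in place of hydrogen on an aromatic carbon, ortho to a methoxy group and meta to a large group, gives a number 2.4 percentage points higher from compound 2 to compound 4 (within the scatter) and is the first one-place step the series offers. At this position, the added methoxy has no effect that can be told from the scatter, and no direction can be read from this single step. No measurement on hand offers an explanation for this result.

The compounds shown leave open whether a different group at this position, such as an amine, a carboxylic acid or a longer alkoxy chain, would give a step beyond the scatter. They also leave open whether the same methoxy step would stay this small on another core, such as that of compound 3.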